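One Methyl Removed from a Compound at the Assay Limit

The source may report more compounds than this note shows. Statements on the series, on what has been measured and on what is new or still open speak of the compounds shown alone.

Three close relatives sharing one core have been tested in a functional assay on HL-60 cells (Homo sapiens) for antiproliferative activity, read by XTT assay, with a stated time of 72 h; a lower number here means a stronger inhibitor, a higher number a weaker inhibitor. Compound 1 `CNc1ncnc2c1c(-c1ccccc1)cn2[C@@H]1O[C@H](CO)[C@@H](O)[C@H]1O` carries a phenyl on an aromatic carbon of that core. In this assay compound 1 gives only a limit, > 20000 nM. Compound 2 `CNc1ncnc2c1c(-c1ccoc1)cn2[C@@H]1O[C@H](CO)[C@@H](O)[C@H]1O` differs by furan-3-yl in place of phenyl on an aromatic carbon. In this assay compound 2 also gives only a limit, > 15000 nM. The step that the two limits leave unreadable from compound 1 to compound 2 therefore cannot be read. Compound 3 `CN(C)c1ncnc2c1c(-c1cc3ccccc3o1)cn2[C@@H]1O[C@H](CO)[C@@H](O)[C@H]1O` carries a dimethylamino group and a different aromatic group on the same core. In this assay compound 3 gives only a limit, > 20000 nM. Within the data shown here, every value so far is such a limit: the limit of > 15000 nM in this assay, at which 1 of the 3 values shown sits, and (the limit of > 20000 nM in this assay, at which 2 of the 3 values shown sit).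

Compound 4 `CNc1ncnc2c1c(-c1cc3ccccc3o1)cn2[C@@H]1O[C@H](CO)[C@@H](O)[C@H]1O` is obtained from compound 3 by hydrogen in place of methyl on a nitrogen on an aromatic ring. Among the measured compounds shown here, no measured step involves this change; the single measured step, a step that the two limits leave unreadable from compound 1 to compound 2, concerns a different position and is unreadable. Compounds 1 and 2 also carry methylamino, and each sits only at a limit in this assay. No step beyond the scatter is therefore expected in this assay, in either direction. Compound 4 is expected to give 30000 nM, between 8000 nM and 100000 nM, most likely again only as a limit. The expected step is a step that the limit leaves unreadable from compound 3 to compound 4.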

Compound 4, half-maximal inhibitory concentration: 8950 nM
Estimate against measurement, compound 4: 3.4-fold (0.53 log units) above; measured number inside the range.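

Taking one methyl off the dimethylamino group, which leaves methylamino, gives an at least 2.2-fold lower number from compound 3 to compound 4 (0.34 log units; beyond the scatter) in this assay and yields the only measured number among the compounds shown. That step is a floor whose true size may be larger, and methylamino does not give a measured number on its own, as compound 1 and compound 2 carry it and remain at limits. The aromatic group also matters: with methylamino kept, 1-benzofuran-2-yl in place of phenyl gives an at least 2.2-fold lower number from compound 1 to compound 4 (0.34 log units; beyond the scatter) and 1-benzofuran-2-yl in place of furan-3-yl gives an at least 1.6-fold lower number from compound 2 to compound 4 (0.22 log units; that floor lies within the scatter) so only the change from phenyl is shown to exceed the usual scatter, while the step between compound 1 and compound 2 cannot be read.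

The compounds shown leave open whether a plain amino group with no methyl on the nitrogen, or a longer chain such as ethylamino, would lower the number further on the 1-benzofuran-2-yl core. Nothing measured here gives a reason for the drop in the number.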